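Mirror-image switch on the ring carbon of compound 3

A few compounds are considered here, and "the series" means these few. Any claim that something is new, unique, unknown or untested is made for them only; others in the source may bear on it.

Measured so far in an ADME assay on RAW264.7 cells (Mus musculus) for cytotoxicity, read by MTT assay, with a stated time of 18 h; on this read-out lower numbers stand for higher toxicity in this test and higher numbers for lower toxicity in this test:
compound 1, `C=C1C(=O)OC[C@H]1CCOC(=O)Nc1ccc(Br)cc1`: 8470 nM
compound 2, `C=C1C(=O)OC[C@H]1CCOC(=O)Nc1ccc(CCCC)cc1`: 15900 nM
compound 3, `C=C1C(=O)OC[C@@H]1CCOC(=O)Nc1ccc(CC)cc1`: 7580 nM

Compound 3 gives the lowest of the three numbers in this assay; its gap to compound 1 lies within the scatter, while the gap to compound 2 lies beyond it. Compound 4, `C=C1C(=O)OC[C@H]1CCOC(=O)Nc1ccc(CC)cc1`, carries the same atoms and bonds: the two compounds have the same atoms and bonds and differ only in configuration as drawn: 1 of 1 stereo elements differ; a stereocentre at a saturated ring carbon is drawn R in compound 3 and S in compound 4. For the measured compounds named here, the only measured step, a 1.9-fold higher number from compound 1 to compound 2 (0.27 log units; within the scatter), swaps a substituent on the aromatic ring and so says nothing about a change of configuration; no measured pair differs in this way. With no guide of that kind, no step beyond the scatter is expected, so a 1.0-fold higher number from compound 3 to compound 4 (0.00 log units; within the scatter) is estimated for this change. Compound 4 is therefore expected to give about 7600 nM in this assay, with a range from 3800 nM to 15000 nM.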

Compound 4, half-maximal cytotoxic concentration: 11400 nM
Estimate against measurement, compound 4: 1.5-fold (0.18 log units) below; the measured number falls inside the stated range.
By their numbers in this assay, from the lowest: compounds 3, 1, 4 and 2 (each within the scatter of the next, the first and the last beyond it).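

For the compounds shown here, this is the first pair to isolate a change of configuration at the saturated ring carbon, and in this assay the switch gives a 1.5-fold higher number from compound 3 to compound 4 (0.18 log units; within the scatter). At this single position, therefore, the effect of the mirror-image switch cannot be told apart from the scatter: the fact that compounds 3 and 4 differ only in the configuration as drawn With the configuration held as in compound 4, changing the group on the aromatic ring also stays small, with a 1.4-fold lower number from compound 2 to compound 4 (0.14 log units; within the scatter) and a 1.3-fold higher number from compound 1 to compound 4 (0.13 log units; within the scatter).

On these data alone, whether the switch stays this small with bromo or butyl on the aromatic carbon remains open. So does what an amine or a carboxylic acid there would give.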